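Moving a Methyl Across the Core of Compound 2

A few compounds are considered here, and "the series" means these few. Any claim that something is new, unique, unknown or untested is made for them only; others in the source may bear on it.

Measured so far in a functional assay on cells (Tumor Cell line, Homo sapiens) for cytotoxicity; on this read-out higher numbers stand for weaker inhibition of growth and lower numbers for stronger inhibition of growth:
compound 1 `COc1ccccc1-c1cc(O)c2cc(C)cnc2n1` – 31600 nM
compound 2 `COc1ccccc1-c1cc(O)c2cccnc2n1` – 40700 nM
compound 3 `COc1ccccc1-c1cc(O)c2c(C)ccnc2n1` – not yet measured

Compounds 1 and 2 share the same core and differ only in one methyl group on an aromatic carbon. Removing it gave a 1.3-fold higher number from compound 1 to compound 2 (0.11 log units; within the scatter), a change too small to be read as real. Compound 2 therefore holds the highest of the two numbers, but its gap to compound 1 is within the scatter, so the two cannot be ranked against each other.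

Compound 3 returns a methyl to the core of compound 2, now at a different spot: methyl in place of hydrogen on an aromatic carbon, on an aromatic carbon of a six-membered aromatic ring with one nitrogen, opposite the ring nitrogen. Going by the values given here, the only step that bears on this is the one from compound 1 to compound 2, in which a methyl left an aromatic carbon without a visible effect. The step of a 1.2-fold lower number from compound 2 to compound 3 (0.07 log units; within the scatter) is therefore expected to be small and could fall in either direction. Compound 3 is estimated to give about 35000 nM, with a range from 14000 nM to 90000 nM.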

Compound 3, concentration for 50% growth inhibition: 2820 nM
Compound 3: the middle estimate sits 12-fold (1.09 log units) above what was measured; the measured number lies below the stated range.
By their numbers in this assay, from the lowest: compound 3; then compounds 1 and 2 (each within the scatter of the next).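

In this assay, a methyl on an aromatic carbon of the shared core does not always leave the number unchanged: placed opposite the ring nitrogen, it gives a 14-fold lower number from compound 2 to compound 3 (1.16 log units; beyond the scatter), which means stronger inhibition of growth. Going by these compounds alone, the earlier step, a 1.3-fold higher number from compound 1 to compound 2 (0.11 log units; within the scatter), concerned the same group on a different aromatic carbon and showed no readable effect, so this pair of steps is the first sign that the place of the methyl counts, and not only its presence. No measurement at hand bears on why this position responds as it does.

The compounds shown leave open whether the stronger inhibition is particular to methyl, a question that an ethyl group, a longer chain, an amine or a carboxylic acid on the same carbon could help to answer. They also leave open whether a methyl opposite the ring nitrogen would produce a step of similar size on a different core or in other tumor cell lines.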